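This account rests on a few compounds, and the source may have more. Where it says the series, first, only, none or still open, it means among the compounds named here.

Compound 1 `CC1=C(C(=O)Nc2ccc(Cl)c(Cl)c2)C(c2cccc(O)c2)NC(=S)N1` gives 14100 nM in a functional assay on PC-3 cells (Homo sapiens) for cytotoxicity, read by sulforhodamine B assay, with a stated time of 48 h; on this read-out higher numbers stand for weaker inhibition of growth and lower numbers for stronger inhibition of growth
Compound 2 `CC1=C(C(=O)Nc2ccc(F)c(Cl)c2)C(c2ccccc2Cl)NC(=S)N1` gives 20400 nM in this assay

Compound 1 holds the lower of the two numbers, but its gap to compound 2 lies within the scatter, so the two cannot be ranked against each other. Compound 3 `CC1=C(C(=O)Nc2ccc(Cl)c(Cl)c2)C(c2cccc(Oc3ccccc3)c2)NC(=S)N1` differs from compound 1 by phenyl in place of hydrogen on an oxygen on an aromatic ring. For the measured compounds named here, no measured pair shows this change, so its effect is unknown; a modest step in either direction, or none beyond the scatter, is expected in this assay. Compound 3 is therefore expected to give 20000 nM, with a range from 6000 nM to 60000 nM. The expected step is a 1.4-fold higher number from compound 1 to compound 3 (0.15 log units; within the scatter).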

Compound 3, concentration for 50% growth inhibition: 9770 nM
For compound 3 the middle estimate is 2.0-fold (0.31 log units) above the measured one; the range from low to high includes it.
By their numbers in this assay, from the lowest: compounds 3, 1 and 2 (each within the scatter of the next, the first and the last beyond it).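

In this assay, going from hydroxy to phenoxy gives a 1.4-fold lower number from compound 1 to compound 3 (0.16 log units; within the scatter). This position on the oxygen therefore accepts a phenyl in place of hydrogen with no shift beyond the scatter, and the hydroxy hydrogen is not required for the growth inhibition seen in compound 1. Nothing at hand explains this outcome. The compounds shown leave open how a methyl, a benzyl or a longer chain on this oxygen would read. They also leave open whether an amine or a carboxylic acid on the added phenyl would move the number beyond the scatter.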